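This account rests on a few compounds, and the source may have more. Where it says the series, first, only, none or still open, it means among the compounds named here.

Measured in a functional assay on K562 cells (Homo sapiens) for cytotoxicity, read by trypan blue exclusion, with a stated time of 96 h; a higher number here means a weaker inhibitor, a lower number a stronger inhibitor:
- compound 1 `COc1cc(OC)c(/C=C/S(=O)(=O)Nc2ccc(OC)c(O)c2)c(OC)c1`: 15 nM
- compound 2 `COC(=O)C(Nc1cc(NS(=O)(=O)/C=C/c2c(OC)cc(OC)cc2OC)ccc1OC)c1ccccc1`: 2500 nM
- compound 3 `COc1cc(OC)c(/C=C/S(=O)(=O)Nc2ccc(OC)c(NC(C)(C)C(=O)O)c2)c(OC)c1`: 5 nM

Compound 3 has the lowest number of the three. Compound 4 `COc1cc(OC)c(/C=C/S(=O)(=O)Nc2ccc(OC)c(NC(C(=O)O)c3ccc(Cl)cc3)c2)c(OC)c1` differs from it by carboxy(4-chlorophenyl)methyl in place of 1-carboxy-1-methylethyl on a nitrogen on an aromatic ring, which places carboxy(4-chlorophenyl)methyl in place of 1-carboxy-1-methylethyl on a nitrogen on an aromatic ring. Among the measured compounds shown here, no measured step isolates this change. The modest 3.0-fold lower number from compound 1 to compound 3 (0.48 log units; beyond the scatter) shows that compound 3 improves on the hydroxy of compound 1. The large 500-fold lower number from compound 2 to compound 3 (2.70 log units; beyond the scatter) is the closest guide, but it swaps out a methoxycarbonyl as well as a ring, and compound 4 keeps the carboxy of compound 3. Only part of that large step is therefore expected to return in this assay, as a 12-fold higher number from compound 3 to compound 4 (1.08 log units; beyond the scatter) upward. Compound 4 is estimated at 60 nM, within a range of 10 nM to 400 nM.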

Compound 4, half-maximal inhibitory concentration: 15 nM
Estimate against measurement, compound 4: 4.0-fold (0.60 log units) above, and the stated range covers the measured number.
By their numbers in this assay, from the lowest: compound 3; then compounds 1 and 4 (each within the scatter of the next); then compound 2.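

In this assay, the nitrogen on an aromatic ring carries a group with a six-membered aromatic ring at only a 3.0-fold higher number from compound 3 to compound 4 (0.48 log units; beyond the scatter), and that group still shows a 170-fold lower number from compound 2 to compound 4 (2.22 log units; beyond the scatter). Against the hydroxy there is no change at the digits printed from compound 1 to compound 4 (within the scatter), so a ring-bearing group on this nitrogen is compatible with low numbers, unlike the one in compound 2. Nothing measured here explains these steps. Still open, going by these compounds, is whether the step from compound 2 rests on the carboxy or the chlorine. An unsubstituted phenyl with a carboxylic acid, or a methyl ester with the 4-chlorophenyl, would separate them.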